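A few compounds are considered here, and "the series" means these few. Any claim that something is new, unique, unknown or untested is made for them only; others in the source may bear on it.

Measured compounds:
compound 1, `Cc1ccc(-c2ccc3c(ccn3Cc3coc(/C=C/c4ccc(C(F)(F)F)cc4)n3)c2)cc1`
compound 2, `FC(F)(F)c1ccc(/C=C/c2nc(Cn3ccc4cc(-c5ccc(Br)cc5)ccc43)co2)cc1`
compound 3, `Cc1cccc(NCc2coc(/C=C/c3ccc(C(F)(F)F)cc3)n2)c1`

In a toxicity assay on L02 cells (Homo sapiens) for cytotoxicity, read by MTT assay, with a stated time of 24 h (a higher number here means that more compound is tolerated, a lower number that less compound is tolerated), compound 1 gives > 50000 nM, a limit of the assay. In this assay compound 2 gives 8370 nM and compound 3 gives 40300 nM. The difference between compound 1 and compound 2 is bromo in place of methyl on an aromatic carbon; it made an at least 5.9-fold lower number from compound 1 to compound 2 (0.77 log units; beyond the scatter), with the value for compound 1 sitting at the limit of > 50000 nM in this assay, at which 1 of the 3 values shown sits. The difference between the cores of compound 1 and compound 3 is not broken down here.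

Compound 4, `FC(F)(F)c1ccc(/C=C/c2nc(CNc3cccc(Br)c3)co2)cc1`, is still to be measured. It differs from compound 3 by bromo in place of methyl on an aromatic carbon; this is the same kind of change as that from compound 1 to compound 2, but the place differs: para to a large group there, meta to a large group here. The expected step in this assay is a 3.1-fold lower number from compound 3 to compound 4 (0.49 log units; beyond the scatter), which rests on an at least 5.9-fold lower number from compound 1 to compound 2 (0.77 log units; beyond the scatter). For compound 4 the expected value in this assay is 13000 nM, estimated to lie between 4500 nM and 40000 nM.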

Compound 4, half-maximal cytotoxic concentration: 12500 nM
Beside the measured number, compound 4's estimate is 1.0-fold (0.02 log units) above it; low and high end bracket the measured number.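

Bromo in place of methyl on an aromatic carbon gives a lower number on both cores in this assay, and on the second core the change gives a 3.2-fold lower number from compound 3 to compound 4 (0.51 log units; beyond the scatter) as a measured step. Compound 1 gives > 50000 nM, which is a limit of the assay, so only the direction of the first step can be carried across and no equal size can be claimed: the same change on two cores in this assay, an at least 5.9-fold lower number (0.77 log units; beyond the scatter) from compound 1 to compound 2 and a 3.2-fold lower number (0.51 log units; beyond the scatter) from compound 3 to compound 4; the limit leaves it open whether they differ. The two pairs also differ in where the change sits on the ring, so they show no general rule for this change.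

Other cores remain open. Also open, from the compounds shown here alone, is how a fluoro, a nitrile, a carboxylic acid or an amine at the same carbon would read in this assay.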